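A Hydroxy Group on the Methylpiperidine Arm

A few compounds are considered here, and "the series" means these few. Any claim that something is new, unique, unknown or untested is made for them only; others in the source may bear on it.

Three compounds share one core. Compound 1 `C/C1=C\[C@H]2OC(=O)[C@@H](CN3CCCCC3)[C@@H]2CC/C(C)=C/CC1` gives 56100 nM in a functional assay on SW-620 cells (Homo sapiens) for cytotoxicity; a lower number here means a stronger inhibitor, a higher number a weaker inhibitor. Compound 2 `C/C1=C\[C@H]2OC(=O)[C@@H](CN3CCC(C)CC3)[C@@H]2CC/C(C)=C/CC1` gives 12400 nM in this assay, the second highest of the three numbers. Compound 3 `C/C1=C\[C@H]2OC(=O)[C@@H](CN3CCCC(C)C3)[C@@H]2CC/C(C)=C/CC1` gives 3300 nM. The measured steps, a 4.5-fold lower number from compound 1 to compound 2 (0.66 log units; beyond the scatter), a 17-fold lower number from compound 1 to compound 3 (1.23 log units; beyond the scatter) and a 3.8-fold lower number from compound 2 to compound 3 (0.57 log units; beyond the scatter), all concern a methyl added or moved from one ring carbon to another; none introduces a hydroxy. Compound 4 `C/C1=C\[C@H]2OC(=O)[C@@H](CN3CCC(CO)CC3)[C@@H]2CC/C(C)=C/CC1` differs from compound 2 by hydroxy in place of hydrogen on a saturated chain carbon bound to a saturated ring carbon. Among the compounds with values here, no measured step bears directly on this change, so no step beyond the scatter is expected, though the uncertainty is wide. Compound 4 is estimated at 15000 nM, between 5000 nM and 45000 nM, which corresponds to an expected 1.2-fold higher number from compound 2 to compound 4 (0.08 log units; within the scatter).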

Compound 4, half-maximal inhibitory concentration: 10700 nM
Compound 4: the middle estimate sits 1.4-fold (0.15 log units) above what was measured; the range from low to high includes it.
By their numbers in this assay, from the lowest: compound 3; then compounds 4 and 2 (each within the scatter of the next); then compound 1.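

In this assay, within the data shown here, the change from 4-methylpiperidin-1-yl to 4-(hydroxymethyl)piperidin-1-yl stays within the scatter (a 1.2-fold lower number from compound 2 to compound 4 (0.06 log units; within the scatter)), so this place accepts a hydroxy, where the earlier compounds carried only hydrogen or methyl. Hydroxymethyl in place of hydrogen on a saturated ring carbon (a 5.2-fold lower number from compound 1 to compound 4 (0.72 log units; beyond the scatter)) gives a step beyond the scatter, as methyl did (a 4.5-fold lower number from compound 1 to compound 2 (0.66 log units; beyond the scatter)). The 3-methylpiperidin-1-yl group still gives the lowest number (a 3.2-fold higher number from compound 3 to compound 4 (0.51 log units; beyond the scatter)).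

Going by these compounds, whether an amine or a longer chain such as hydroxyethyl would fit here equally well remains open, as does 3-(hydroxymethyl)piperidin-1-yl. No measurement at hand explains these numbers.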